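Hydroxyalkyl Chain Variations on a Fused Bicyclic Core

The compounds below may be only part of what the source reports. "The series", "measured", "known", "first", "only" and "open" are said of these compounds alone.

Compound 1 `CC(C)Cn1c(=O)n(C)c(=O)c2nc(SCCCCO)c(Cc3cccc4ccccc34)nc21` — 669 nM
Compound 2 `CC(C)Cn1c(=O)n(C)c(=O)c2nc(CCCCCCO)c(Cc3cccc4ccccc34)nc21` — "not determined" (no result reported)

In an assay on MCF7 cells for inhibition of Monocarboxylate transporter 1 (Homo sapiens), read by scintillation counting, with a stated time of 10 min (on this read-out lower numbers stand for stronger inhibition and higher numbers for weaker inhibition), compound 1 gives 669 nM. Compound 2 carries a 6-hydroxyhexyl chain on the same ring carbon where compound 1 holds a sulfur-linked chain, but in this assay compound 2 gives "not determined" (no result reported), so it stands without a value, and nothing can be said of how it compares with compound 1. Compound 3 `CC(C)Cn1c(=O)n(C)c(=O)c2nc(/C=C\CCCO)c(Cc3cccc4ccccc34)nc21` differs from compound 2 by 5-hydroxypent-1-en-1-yl in place of 6-hydroxyhexyl on an aromatic carbon: the chain changes from 6-hydroxyhexyl to 5-hydroxypent-1-en-1-yl, keeping one hydrogen-bond donor and one hydrogen-bond acceptor, with the hydroxyl remaining at the far end. Among the measured compounds shown here, with no measured pair to show how such a chain change shifts this assay, and with compound 2 itself unmeasured, the only anchor is compound 1. The step from compound 2 to compound 3 is therefore expected to be small, within the usual scatter, in no definite direction. Compound 3 is estimated at 1000 nM in this assay, with a range from 250 nM to 4000 nM.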

Compound 3, half-maximal inhibitory concentration: 116 nM
Compound 3: the middle estimate sits 8.6-fold (0.94 log units) above what was measured; the whole stated range lies above it.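

The step of a 5.8-fold lower number from compound 1 to compound 3 (0.76 log units; beyond the scatter) in this assay gives the first readable result at this position, where 5-hydroxypent-1-en-1-yl replaces (4-hydroxybutyl)sulfanyl on the aromatic carbon. It shows that the number in this assay responds to the chain held here, even though both chains end in a hydroxyl, and that a chain with no sulfur link and one double bond outside aromatic rings is compatible with the lower number. Nothing given here accounts for the shift, and no measured property bears on it.

The step from compound 2 to compound 3 cannot be read, as compound 2 has no value, so the effect of the double bond cannot be separated from that of removing the sulfur link, and the saturated 6-hydroxyhexyl chain remains unplaced relative to the other two. The compounds shown also leave open how this position would respond to an amine or a carboxylic acid in place of the hydroxyl at the far end of the chain, or to a longer chain.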